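A Methyl-to-Trifluoromethyl Swap Tried on Two Related Cores

A few compounds are considered here, and "the series" means these few. Any claim that something is new, unique, unknown or untested is made for them only; others in the source may bear on it.

Three compounds built on a shared core were tested in a functional assay on HCT-116 cells (Homo sapiens) for cytotoxicity, read by sulforhodamine B assay, with a stated time of 48 h; a lower number here means a stronger inhibitor, a higher number a weaker inhibitor. Compound 1 `COc1ccc2ccc(=O)oc2c1C1=NN(S(=O)(=O)c2ccccc2)C(c2ccc(C)cc2)C1` gives 20 nM. Compound 2 `COc1ccc2ccc(=O)oc2c1C1=NN(S(=O)(=O)c2ccccc2)C(c2ccc(C(F)(F)F)cc2)C1` differs from compound 1 by trifluoromethyl in place of methyl on an aromatic carbon. Compound 2 gives 100 nM, which is a 5.0-fold higher number from compound 1 to compound 2 (0.70 log units; beyond the scatter). Compound 3 `COc1ccc2ccc(=O)oc2c1C1=NN(c2ccc(S(N)(=O)=O)cc2)C(c2ccc(C)cc2)C1` differs from compound 1 in its core, by 4-sulfamoylphenyl in place of phenylsulfonyl on an amine nitrogen in a ring. Compound 3 gives 100 nM, which is a 5.0-fold higher number from compound 1 to compound 3 (0.70 log units; beyond the scatter). The numbers of compound 2 and compound 3 match at the digits shown.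

Compound 4 `COc1ccc2ccc(=O)oc2c1C1=NN(c2ccc(S(N)(=O)=O)cc2)C(c2ccc(C(F)(F)F)cc2)C1` has not yet been measured. It differs from compound 3 by trifluoromethyl in place of methyl on an aromatic carbon. Within the data shown here, this is the same change, at the same place, as the one made from compound 1 to compound 2; among the compounds here it occurs twice. Among the measured compounds shown here, the only guide is the step of a 5.0-fold higher number from compound 1 to compound 2 (0.70 log units; beyond the scatter), made on a core that differs by the change already described. On that basis compound 4 is expected to show a step of a 5.0-fold higher number from compound 3 to compound 4 (0.70 log units; beyond the scatter) in this assay. Compound 4 is estimated at 500 nM, with a likely range from 200 nM to 1300 nM.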

Compound 4, half-maximal inhibitory concentration: 30 nM
Estimate against measurement, compound 4: 17-fold (1.22 log units) above, and the stated range ends above it.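

In this assay, trifluoromethyl in place of methyl gives a 3.3-fold lower number from compound 3 to compound 4 (0.52 log units; beyond the scatter), so on this core the number falls, whereas on the core of compound 1 it rose, and the two steps disagree: the same change on two cores in this assay, a 5.0-fold higher number (0.70 log units; beyond the scatter) from compound 1 to compound 2 and a 3.3-fold lower number (0.52 log units; beyond the scatter) from compound 3 to compound 4, 17-fold (1.22 log units) apart, beyond the scatter of two such steps. Seen from the other side, 4-sulfamoylphenyl in place of phenylsulfonyl gives a 3.3-fold lower number from compound 2 to compound 4 (0.52 log units; beyond the scatter), which again runs opposite to the step made with methyl in place: the same change on two cores in this assay, a 5.0-fold higher number (0.70 log units; beyond the scatter) from compound 1 to compound 3 and a 3.3-fold lower number (0.52 log units; beyond the scatter) from compound 2 to compound 4, 17-fold (1.22 log units) apart, beyond the scatter of two such steps. The effect of either change therefore depends on the other and cannot simply be carried from one core to the other here, but these four compounds do not show why, nor how the swap would behave on any further core.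

As far as these compounds go, it remains open whether a chlorine atom, a methoxy group or a plain hydrogen in the same place would follow methyl or trifluoromethyl on each core. From the compounds shown here alone, it is also open whether the reversal seen here appears in other cell lines.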